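Cytotoxicity of amide variants on a shared chromone core

A few compounds are considered here, and "the series" means these few. Any claim that something is new, unique, unknown or untested is made for them only; others in the source may bear on it.

Measured so far in an ADME assay on HepG2 2.2.15 cells (Homo sapiens) for cytotoxicity, read by MTT assay, with stated times of 48 h and 9 days; on this read-out lower numbers stand for higher toxicity in this test and higher numbers for lower toxicity in this test:
compound 1 `COc1ccc2c(=O)c(/C=C/C(=O)NCc3ccccc3)coc2c1`: 376000 nM
compound 2 `COc1cccc(NC(=O)/C=C/c2coc3cc(OC)ccc3c2=O)c1`: 1130000 nM
compound 3 `COc1ccc(NC(=O)/C=C/c2coc3cc(OC)ccc3c2=O)cc1`: 718000 nM

Compound 1 carries a benzyl group on the amide-type nitrogen and stands lowest of the three numbers in this assay. Its nearest neighbour is compound 3, which gives 718000 nM; the step of a 1.9-fold higher number from compound 1 to compound 3 (0.28 log units; within the scatter) stays within the scatter. Compound 2 lies furthest from it: the step of a 3.0-fold higher number from compound 1 to compound 2 (0.48 log units; beyond the scatter) is modest but beyond the scatter. Between the two aryl amides the step of a 1.6-fold lower number from compound 2 to compound 3 (0.20 log units; within the scatter) is within the scatter.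

Compound 4 `CCOc1ccc(NC(=O)/C=C/c2coc3cc(OC)ccc3c2=O)cc1` is not yet measured. It differs from compound 1 as follows: 4-ethoxyphenyl in place of benzyl on an amide-type nitrogen

Going by the values given here, the steps that bear on this change are the two in which a methoxyphenyl replaces benzyl, a 3.0-fold higher number from compound 1 to compound 2 (0.48 log units; beyond the scatter) and a 1.9-fold higher number from compound 1 to compound 3 (0.28 log units; within the scatter). Both moved the number upward, one within the scatter and one beyond it. The 4-ethoxyphenyl group is closest in kind to the 4-methoxyphenyl of compound 3, so for compound 4 a step of similar size and direction is expected in this assay: a 1.9-fold higher number from compound 1 to compound 4 (0.27 log units; within the scatter). Compound 4 is therefore estimated at 700000 nM, with a range of 300000 nM to 1500000 nM.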

Compound 4, half-maximal cytotoxic concentration: 460000 nM
For compound 4 the middle estimate is 1.5-fold (0.18 log units) above the measured one; the measured number falls inside the stated range.
By their numbers in this assay, from the lowest: compounds 1, 4, 3 and 2 (each within the scatter of the next, the first and the last beyond it).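

In this assay the 4-ethoxyphenyl amide cannot be told from the benzyl amide (a 1.2-fold higher number from compound 1 to compound 4 (0.09 log units; within the scatter)), so a larger aryl ether group on the amide-type nitrogen does not by itself separate from benzyl. Methyl in place of hydrogen on the saturated chain carbon bound to the oxygen also gives no readable change (a 1.6-fold lower number from compound 3 to compound 4 (0.19 log units; within the scatter)), which is the first look at the alkoxy chain itself in this series. Going by these compounds alone, the one step here beyond the scatter (a 2.5-fold lower number from compound 2 to compound 4 (0.39 log units; beyond the scatter)) changes both the name of the ring position and the chain at once, so it cannot be assigned to either, and compound 3 stands within the scatter of compound 1, compound 2 and compound 4 alike, against any clean split of the series.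

Nothing at hand accounts for these small differences. On these data alone, whether a longer alkoxy chain such as butoxy, or an amine or a carboxylic acid on the aryl ring, would move the number clearly beyond the scatter remains open.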